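This account rests on a few compounds, and the source may have more. Where it says the series, first, only, none or still open, it means among the compounds named here.

In an ADME assay on HaCaT cells (Homo sapiens) for cytotoxicity, read by MTT assay, with a stated time of 72 h (a lower number here means a stronger inhibitor, a higher number a weaker inhibitor), compound 1 `Cc1cccc(CSc2cc(Cl)c(C)cc2S(=O)(=O)/N=C(\N)n2nccc2-c2ccccc2)c1` gives 10000 nM, compound 2 `Cc1cc(S(=O)(=O)/N=C(\N)n2nccc2-c2ccccc2)c(SCc2cccc(Cl)c2)cc1Cl` gives 10000 nM, and compound 3 `Cc1cc(S(=O)(=O)/N=C(\N)n2nccc2-c2ccccc2)c(SCc2cccc3ccccc23)cc1Cl` gives 11000 nM; the three numbers sit together within the scatter, so compound 3 is set apart from neither. Compound 4 `Cc1ccc(CSc2cc(Cl)c(C)cc2S(=O)(=O)/N=C(\N)n2nccc2-c2ccccc2)cc1` differs from compound 3 by 4-methylphenyl in place of naphthalen-1-yl on a saturated chain carbon bound to a sulfur. For the measured compounds named here, the steps that bear on this are the ones into the naphthalen-1-yl group: a 1.1-fold higher number from compound 1 to compound 3 (0.04 log units; within the scatter) and a 1.1-fold higher number from compound 2 to compound 3 (0.04 log units; within the scatter), both flat, and no change at the digits printed from compound 1 to compound 2 (within the scatter) shows that swapping a substituent on that phenyl ring changes nothing either. Returning from naphthalen-1-yl to a methylphenyl group is therefore expected to give no step beyond the scatter in this assay, a 1.1-fold lower number from compound 3 to compound 4 (0.04 log units; within the scatter). Compound 4 is estimated at 10000 nM, with a range from 5000 nM to 20000 nM.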

Compound 4, half-maximal inhibitory concentration: 20000 nM
Compound 4: middle estimate off by 2.0-fold (0.30 log units), on the low side, within the range that was stated.
By their numbers in this assay, from the lowest: compounds 1, 2, 3 and 4 (each within the scatter of the next).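

In this assay the 4-methylphenyl group on a saturated chain carbon bound to a sulfur gives a 1.8-fold higher number from compound 3 to compound 4 (0.26 log units; within the scatter) and a 2.0-fold higher number from compound 2 to compound 4 (0.30 log units; within the scatter) and a 2.0-fold higher number from compound 1 to compound 4 (0.30 log units; within the scatter) and so stays within the scatter of all three earlier groups. Neither replacing naphthalen-1-yl with a single six-membered aromatic ring nor exchanging 3-methylphenyl for 4-methylphenyl separates these compounds. No measurement here explains these steps. The compounds shown leave open whether an amine or a carboxylic acid in place of the aromatic group would step beyond the scatter in this assay. Going by these compounds, a longer chain between the sulfur and the aromatic ring remains equally open.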